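This account rests on a few compounds, and the source may have more. Where it says the series, first, only, none or still open, it means among the compounds named here.

Among the compounds with values here, compound 2 `NS(=O)(=O)Oc1ccc2c(c1)CN(C(=O)c1cccc(N3CCCCC3)c1)CC2` holds the highest of the two numbers so far in an assay on HEK293 cells for inhibition of Steryl-sulfatase (Homo sapiens), tested at 1 uM (a higher number here means a stronger effect of the compound at the concentration tested, a lower number a weaker effect), where compound 2 gives 11.9%. Within the data shown here, its only neighbour is compound 1 `NS(=O)(=O)Oc1ccc2c(c1)CN(C(=O)c1cccc(N3CCC(N4CCCCC4)CC3)c1)CC2`, which in this assay gives 8%; the step of a number 3.9 percentage points higher from compound 1 to compound 2 (within the scatter) arose from replacing piperidin-1-yl with hydrogen on a saturated ring carbon and stayed within the scatter. Compound 3 `NS(=O)(=O)Oc1ccc2c(c1)CN(C(=O)c1cccc(N3CCC(Cc4ccccc4)CC3)c1)CC2` differs from compound 2 by benzyl in place of hydrogen on a saturated ring carbon. Among the measured compounds shown here, only the step from compound 1 to compound 2 bears on this, and it shows that a large group on that saturated ring carbon left the read-out essentially unchanged; no measured pair shows what benzyl does there. The account therefore expects compound 3 to show a step of a number 1.1 percentage points higher from compound 2 to compound 3 (within the scatter) that does not reach beyond the scatter, and the estimate for compound 3 in this assay is 13%, with a range from 2% to 30%.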

Compound 3, a percentage reported as inhibition, at one concentration (the size of the read-out at that concentration, not a potency): 41.9%
Compound 3: middle estimate off by 28.9 percentage points, on the low side, and the stated range ends below it.
By their numbers in this assay, from the lowest: compounds 1 and 2 (each within the scatter of the next); then compound 3.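

In this assay, the saturated ring carbon three ring bonds from the ring nitrogen proves responsive to what it carries, which the earlier pair, with its step within the scatter, did not reveal: benzyl in place of hydrogen gives a number 30 percentage points higher from compound 2 to compound 3 (beyond the scatter) on the shared core. A large group on that carbon does not by itself raise the read-out, since benzyl in place of piperidin-1-yl gives a number 33.9 percentage points higher from compound 1 to compound 3 (beyond the scatter) and so separates two large groups at the same place. Nothing available explains why benzyl and piperidin-1-yl differ here. As far as these compounds go, it remains open whether the read-out depends on the carbon link of benzyl, as phenyl attached directly or a longer phenethyl chain would show. Also open, from the compounds shown here alone, is what a fluorine or a methoxy group on the benzyl ring would do.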